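This account rests on a few compounds, and the source may have more. Where it says the series, first, only, none or still open, it means among the compounds named here.

Of the compounds shown here, three have so far been measured in an assay on HEK293 cells for displacement of a labelled ligand from 5-hydroxytryptamine receptor 7 (Homo sapiens), read by scintillation counting, with a stated time of 1 h; on this read-out lower numbers stand for stronger inhibition and higher numbers for weaker inhibition. Compound 1 `CC(C)c1ccccc1OCC(C)N1CCC(NS(=O)(=O)c2cccc(F)c2)CC1` gives 170 nM, compound 2 `CC(C)c1ccccc1OCCCN1CCC(NS(=O)(=O)c2ccc(F)cc2)CC1` gives 32 nM, and compound 3 `O=S(=O)(NC1CCN(CCCOc2ccccc2-c2ccccc2)CC1)c1cccc(Cl)c1` gives 52 nM. On these three numbers compound 3 lies between the other two: its gap to compound 2 falls within the usual scatter of repeated measurements, so the two cannot be told apart, whereas compound 1 sits beyond the scatter on the side of weaker binding.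

Compound 4 `O=S(=O)(NC1CCN(CCCOc2ccccc2-c2ccccc2)CC1)c1ccc(F)cc1` has not yet been measured. It differs from compound 3 in one place: 4-fluorophenyl in place of 3-chlorophenyl on a sulfonyl sulfur. Within the data shown here, no measured pair shows this exact change on its own, so no step size is known for it. Compound 2 carries the same 4-fluorophenyl group on a sulfonyl sulfur, attached to a different core, and gives 32 nM, a number close to that of compound 3, so a shift within the scatter, if any, seems the most likely outcome. For compound 4 in this assay the expected value is 40 nM, with a range from 15 nM to 120 nM. That expectation amounts to a 1.3-fold lower number from compound 3 to compound 4 (0.11 log units; within the scatter), a step expected to stay within the scatter.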

Compound 4, inhibition constant: 58 nM
Compound 4: middle estimate off by 1.5-fold (0.16 log units), on the low side; measured number inside the range.
By their numbers in this assay, from the lowest: compounds 2, 3 and 4 (each within the scatter of the next); then compound 1.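

In this assay, the exchange of 3-chlorophenyl for 4-fluorophenyl on a sulfonyl sulfur gives a 1.1-fold higher number from compound 3 to compound 4 (0.05 log units; within the scatter), so with this core the two groups cannot be told apart. The other single exchange, phenyl in place of isopropyl on an aromatic carbon, gives a 1.8-fold higher number from compound 2 to compound 4 (0.26 log units; within the scatter), so with 4-fluorophenyl on the sulfonyl sulfur these two groups cannot be told apart either. Nothing at hand explains why neither exchange produces a difference that can be read.

Still open, on these data alone, is whether a different group on the sulfonyl sulfur, such as unsubstituted phenyl, 4-chlorophenyl or 4-methoxyphenyl, would give a clear difference. Among these compounds, the chain of compound 1 also has no step of its own, since compound 1 differs from every other compound in more than one place.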